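Methyl to 3-Phenylpropyl on a Shared Core

The compounds below may be only part of what the source reports. "The series", "measured", "known", "first", "only" and "open" are said of these compounds alone.

Three measured compounds share one core and differ only in the aromatic group attached to it. In a functional assay on HCT-116 cells (Homo sapiens) for inhibition, read by MTT assay, with a stated time of 2 days, tested at 10 uM (on this read-out higher numbers stand for more inhibition at the one concentration tested (going by the name of the read-out) and lower numbers for less inhibition), compound 1 `COC(=O)c1cc(-n2cc(-c3cc(O)ccc3O)nn2)ccc1O` gives 15%, compound 2 `COC(=O)c1cc(-n2cc(-c3ccc(OC)cc3)nn2)ccc1O` gives 6%, and compound 3 `COC(=O)c1cc(-n2cc(-c3cccc(O)c3)nn2)ccc1O` gives 6%. Compound 2 thus stands level with compound 3 at the digits shown, the two together being the lowest of the three numbers, while the step of a number 9 percentage points lower from compound 1 to compound 2 (within the scatter) lies within the scatter, as does no change at the digits printed from compound 2 to compound 3 (within the scatter). All measured steps exchange one aromatic group for another at the same place; none of them touches the saturated chain carbon bound to an oxygen next to a carbonyl group. Compound 4 `COc1ccc(-c2cn(-c3ccc(O)c(C(=O)OCCCc4ccccc4)c3)nn2)cc1` differs from compound 2 exactly there: phenethyl in place of hydrogen on a saturated chain carbon bound to an oxygen next to a carbonyl group; cut one bond further out, the difference reads methyl to 3-phenylpropyl. Among the compounds with values here, no measured step bears on this change, so the only guide is that every measured compound sits low. The step of a number 2 percentage points higher from compound 2 to compound 4 (within the scatter) is therefore expected to lie within the scatter. Compound 4 is estimated at 8% in this assay, within 0% to 25%.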

Compound 4, a percentage reported as inhibition, at one concentration (the size of the read-out at that concentration, not a potency): 12%
For compound 4 the middle estimate is 4 percentage points below the measured one, within the range that was stated.
By their numbers in this assay, from the lowest: compounds 2, 3, 4 and 1 (each within the scatter of the next).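

Within the data shown here, the place on a saturated chain carbon bound to an oxygen next to a carbonyl group now has a measured change, which none of the earlier steps among the aromatic groups could give. In this assay, methyl to 3-phenylpropyl gives a number 6 percentage points higher from compound 2 to compound 4 (within the scatter), so even this added phenethyl, with its 8 heavy atoms and one six-membered aromatic ring, moves the number by no more than the scatter. No measurement shown here offers an explanation for this result.

This single change, made on one aromatic group, cannot show how a shorter chain such as ethyl, or a chain ending in an amine, would read at this place. Also open, from the compounds shown here alone, is whether a carboxylic acid in place of the methyl ester would read any differently, or whether 3-phenylpropyl would read the same alongside the 2,5-dihydroxyphenyl group of compound 1.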